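Replacing the ethenyl arm of compound 2 with phenyl

The source may report more compounds than this note shows. Statements on the series, on what has been measured and on what is new or still open speak of the compounds shown alone.

In an ADME assay on BaF3 cells (Mus musculus) for antiproliferative activity, read by CCK-8 assay, with a stated time of 72 h (a lower number here means a stronger inhibitor of growth, a higher number a weaker inhibitor of growth), compound 1 (`Cc1ccc(NC(=O)CCSc2ccc3c(/C=C/c4ccccn4)n[nH]c3c2)cc1C(F)(F)F`) gives 530 nM, compound 2 (`CN1CCN(Cc2ccc(NC(=O)CCSc3ccc4c(/C=C/c5ccccn5)n[nH]c4c3)cc2C(F)(F)F)CC1`) gives 2480 nM and compound 3 (`CC1CCN(Cc2ccc(NC(=O)CCSc3ccc4c(/C=C/c5ccccn5)n[nH]c4c3)cc2C(F)(F)F)CC1`) gives 4170 nM. Compound 2 therefore stands level with compound 3, the step being a 1.7-fold higher number from compound 2 to compound 3 (0.23 log units; within the scatter), and clearly apart from compound 1.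

Compound 4 (`CN1CCN(Cc2ccc(NC(=O)CCSc3ccc4c(-c5ccccc5)n[nH]c4c3)cc2C(F)(F)F)CC1`) keeps the 4-methylpiperazin-1-yl group of compound 2 and differs by phenyl in place of 2-(pyridin-2-yl)ethenyl on an aromatic carbon: phenyl in place of 2-(pyridin-2-yl)ethenyl, on an aromatic carbon of the five-membered aromatic ring with 2 nitrogen.

Going by the values given here, no measured step touches this place. All three concern a saturated chain carbon, so they offer only a guide to size, namely a 4.7-fold higher number from compound 1 to compound 2 (0.67 log units; beyond the scatter) and a 7.9-fold higher number from compound 1 to compound 3 (0.90 log units; beyond the scatter). The data do not fix a direction, and a modest rise in this assay is the working expectation, held loosely. The expected step is a 1.6-fold higher number from compound 2 to compound 4 (0.21 log units; within the scatter). For compound 4 the estimated value is 4000 nM, with an expected range of 1000 nM to 12000 nM.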

Compound 4, concentration for 50% growth inhibition: 600 nM
Compound 4: middle estimate off by 6.7-fold (0.82 log units), on the high side, outside the stated range (below it).
By their numbers in this assay, from the lowest: compounds 1 and 4 (each within the scatter of the next); then compounds 2 and 3 (each within the scatter of the next).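

Going by these compounds alone, the aromatic carbon of the five-membered aromatic ring with 2 nitrogen proves responsive in this assay: phenyl in place of 2-(pyridin-2-yl)ethenyl gives a 4.1-fold lower number from compound 2 to compound 4 (0.62 log units; beyond the scatter), a first step at this place, and it runs towards stronger inhibition of growth with the 4-methylpiperazin-1-yl group kept. The change removes the double bond outside aromatic rings and the ring nitrogen together, so the 2-(pyridin-2-yl)ethenyl arm is not required for this level of activity in compound 4. No measurement at hand explains the step.

Which of the two removed features accounts for the step stays open, and a pyridin-2-yl ring placed directly on that carbon, or a phenyl carrying an amine, would separate them. Whether the same step holds alongside the 4-methylpiperidin-1-yl group of compound 3 also remains unsettled.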